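A few compounds are considered here, and "the series" means these few. Any claim that something is new, unique, unknown or untested is made for them only; others in the source may bear on it.

Measured so far:
compound 1, `CC(C(=O)NCc1ccc(C(F)(F)F)nc1-c1cccc(Cl)c1)c1ccc(NS(C)(=O)=O)c(F)c1`: 0.5 nM in an assay on CHO cells for antagonist activity at transient receptor potential cation channel subfamily V member 1 (Homo sapiens), read by FLIPR; on this read-out lower numbers stand for stronger inhibition and higher numbers for weaker inhibition
compound 2, `COc1ccc(-c2nc(C(F)(F)F)ccc2CNC(=O)C(C)c2ccc(NS(C)(=O)=O)c(F)c2)cc1OC`: 25.6 nM in this assay

Among the measured compounds shown here, compound 2 stands at the highest of the two numbers in this assay; its only neighbour is compound 1, and the one known step, a 51-fold higher number from compound 1 to compound 2 (1.71 log units; beyond the scatter), is large and well beyond the scatter. Compound 3, `CC(C(=O)NCc1ccc(C(F)(F)F)nc1-n1ccnc1)c1ccc(NS(C)(=O)=O)c(F)c1`, differs from compound 2 by 1H-imidazol-1-yl in place of 3,4-dimethoxyphenyl on an aromatic carbon. For the measured compounds named here, the single measured step concerns the same place on the shared core and shows that what sits there moves the number strongly, so a step of real size is expected here too; no measured compound carries a five-membered group at that place, so the direction rests on that one step alone. Compound 3 is expected to give about 100 nM in this assay, with a range from 10 nM to 1000 nM. That estimate amounts to a 3.9-fold higher number from compound 2 to compound 3 (0.59 log units; beyond the scatter), an expected further weakening.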

Compound 3, inhibition constant: 36.1 nM
The estimate for compound 3 lay 2.8-fold (0.44 log units) above the measured number; low and high end bracket the measured number.
By their numbers in this assay, from the lowest: compound 1; then compounds 2 and 3 (each within the scatter of the next).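

In this assay, exchanging 3,4-dimethoxyphenyl for the smaller 1H-imidazol-1-yl at this place next to the ring nitrogen gives a 1.4-fold higher number from compound 2 to compound 3 (0.15 log units; within the scatter) and so leaves no difference that can be read, despite the change in ring size and atom types. Among the compounds shown here, the replacement of 3-chlorophenyl gives a 72-fold higher number from compound 1 to compound 3 (1.86 log units; beyond the scatter) and is large, so among the three compounds, the low number is seen only with 3-chlorophenyl, and the earlier large step is not peculiar to the dimethoxyphenyl group. No measurement offered here accounts for this outcome.

The compounds shown leave open whether the low number depends on the chlorine atom or on the phenyl ring itself, which a plain phenyl or a 3-fluorophenyl group would address. They also leave open how a saturated amine such as piperidine would fare at this place.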